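Notes on the amine substituent in the benzamide series

This account rests on a few compounds, and the source may have more. Where it says the series, first, only, none or still open, it means among the compounds named here.

Measured so far in a functional assay on the whole organism for antagonist activity, with Mus musculus as the target; a higher number here means that more compound is needed for the effect, a lower number that less compound is needed:
compound 1 `COc1cc(N)c(Cl)cc1NC(=O)C1CCN(CC2CC2)CC1` gives > 10 mg/kg, a limit of the assay.
compound 2 `COc1cc(N)c(Cl)cc1NC(=O)C1CCN(C/C=C/c2ccccc2)CC1` gives > 10 mg/kg, again a limit.
compound 3 `COc1cc(N)c(Cl)cc1NC(=O)C1CCN(Cc2ccc(Cl)cc2)CC1` gives 1.2 mg/kg.

Within the data shown here, compound 3 holds the only number in this set; the other two values sit at the limit of > 10 mg/kg in this assay, at which 2 of the 3 values shown sit. Compound 4 `CCCCN1CCC(C(=O)Nc2cc(Cl)c(N)cc2OC)CC1` differs from compound 3 by propyl in place of 4-chlorophenyl on a saturated chain carbon bound to an amine nitrogen in a ring. The step that bears on this is an at least 8.3-fold lower number from compound 1 to compound 3 (0.92 log units; beyond the scatter), where the group without a ring gave only a limit and 4-chlorophenyl gave a readable dose; compound 2 likewise sits at the limit. Propyl, like cyclopropyl, carries no ring, so compound 4 is expected to move back toward the limit, a 6.7-fold higher number from compound 3 to compound 4 (0.82 log units; beyond the scatter), with a fair chance that only a limit is reported. The estimate for compound 4 is 8 mg/kg, between 3 mg/kg and 30 mg/kg.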

Compound 4, dose for half-maximal effect: > 10 mg/kg
Compound 4: a limit, no number (the forecaster's own chance of this, stated with the estimate: 50%); middle value at least 1.2-fold (0.09 log units) away from the limit.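

Compound 4 gives only a limit in this assay, so an open chain joins cyclopropyl and 2-phenylethenyl at this position. Propyl in place of 4-chlorophenyl is an at least 8.3-fold higher number from compound 3 to compound 4 (0.92 log units; beyond the scatter), while the steps among compound 1, compound 2 and compound 4 cannot be read. Compound 3 alone keeps a number, and the set now stands at: the limit of > 10 mg/kg in this assay, at which 3 of the 4 values shown sit.

Compound 2 carries an aromatic ring yet sits at a limit, so an aromatic ring alone does not give a number here. As far as these compounds go, whether the chlorine matters stays open; a plain phenyl or a 4-methoxyphenyl at this place would bear on that.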